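Piperazin-1-yl for pyrrolidin-1-yl: working notes on the series

The source may report more compounds than this note shows. Statements on the series, on what has been measured and on what is new or still open speak of the compounds shown alone.

Measured so far in an ADME assay on cells (Astrocyte, Rattus norvegicus, strain Wistar) for inhibition, read by sulforhodamine B assay, with a stated time of 72 h; a higher number here means that more compound is tolerated, a lower number that less compound is tolerated
compound 1 (`CCCCc1ccc(C(=O)/C=C/c2ccc([N+](=O)[O-])o2)cc1`) gives 41200 nM
compound 2 (`O=C(/C=C/c1ccc([N+](=O)[O-])o1)c1ccc(-n2ccnc2)cc1`) gives 45300 nM
compound 3 (`O=C(/C=C/c1ccc([N+](=O)[O-])o1)c1ccc(N2CCCC2)cc1`) gives 65800 nM

Compound 3 lies within the scatter of both other compounds, as the steps show (a 1.6-fold higher number from compound 1 to compound 3 (0.20 log units; within the scatter) and a 1.5-fold higher number from compound 2 to compound 3 (0.16 log units; within the scatter)). The next change leads to compound 4 (`O=C(/C=C/c1ccc([N+](=O)[O-])o1)c1ccc(N2CCNCC2)cc1`), with piperazin-1-yl in place of pyrrolidin-1-yl on an aromatic carbon, para to a large group (piperazin-1-yl in place of pyrrolidin-1-yl on an aromatic carbon). The two steps above bear on this change, together with a third exchange on the same kind of carbon (a 1.1-fold higher number from compound 1 to compound 2 (0.04 log units; within the scatter)). All three exchanges among butyl, 1H-imidazol-1-yl and pyrrolidin-1-yl stay within the scatter. Among the measured compounds shown here, no measured compound carries piperazin-1-yl, so this group remains untested. No step beyond the scatter is therefore expected in this assay, and the data favour no clear direction. The estimated step stays small (a 1.2-fold lower number from compound 3 to compound 4 (0.08 log units; within the scatter)). Compound 4 is estimated at 55000 nM (expected range 28000 nM to 105000 nM).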

Compound 4, half-maximal cytotoxic concentration: 44300 nM
Estimate against measurement, compound 4: 1.2-fold (0.09 log units) above; the measured number falls inside the stated range.
By their numbers in this assay, from the lowest: compounds 1, 4, 2 and 3 (each within the scatter of the next).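

In this assay piperazin-1-yl on this aromatic carbon, para to a large group, gives no step beyond the scatter from any of the three groups already compared here (a 1.5-fold lower number from compound 3 to compound 4 (0.17 log units; within the scatter); a 1.0-fold lower number from compound 2 to compound 4 (0.01 log units; within the scatter); a 1.1-fold higher number from compound 1 to compound 4 (0.03 log units; within the scatter)). This change brings in a second ring nitrogen and 1 hydrogen-bond donor, against 0 for pyrrolidin-1-yl, and all exchanges now shown among the four groups at this position stay within the scatter. No accompanying measurement bears on this result, so the compounds offer no account of it.

Going by these compounds, what a carboxylic acid or a longer alkyl chain at this position would give remains open. Also open, on these data alone, is whether a change elsewhere on the shared core, such as replacing the nitro group, would give a step beyond the scatter.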